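The source may report more compounds than this note shows. Statements on the series, on what has been measured and on what is new or still open speak of the compounds shown alone.

Values in a functional assay on A549 cells (Homo sapiens) for antiproliferative activity, read by MTT assay, with a stated time of 48 h; a lower number here means a stronger inhibitor, a higher number a weaker inhibitor:
- compound 1 `COc1cccc(-c2nn(-c3ccccc3)cc2C(Nc2nc3ccccc3s2)c2c(O)ccc3ccccc23)c1` gives 24800 nM
- compound 2 `COc1cccc(-c2nn(-c3ccccc3)cc2C(Nc2nc3ccc(OC)cc3s2)c2c(O)ccc3ccccc23)c1` gives 88100 nM
- compound 3 `O=[N+]([O-])c1cccc(-c2nn(-c3ccccc3)cc2C(Nc2nc3ccc(Cl)cc3s2)c2c(O)ccc3ccccc23)c1` gives 42500 nM
- compound 4 `COc1cccc(-c2nn(-c3ccccc3)cc2C(Nc2nc3ccc(Cl)cc3s2)c2c(O)ccc3ccccc23)c1` is not yet measured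

Compound 3 at 42500 nM lies within the scatter of compound 1, while compound 2 gives a higher number, beyond the scatter. The change to compound 4 is methoxy in place of nitro on an aromatic carbon, meta to a large group, or 3-nitrophenyl to 3-methoxyphenyl.

Among the measured compounds shown here, no measured step makes this exchange. For the measured compounds named here, the only step available, a 3.6-fold higher number from compound 1 to compound 2 (0.55 log units; beyond the scatter), is methoxy in place of hydrogen at another place in the molecule, so it bears only loosely. Compound 1 and compound 2 both carry the 3-methoxyphenyl, and compound 3 falls inside the span of their two values. No step beyond the scatter is therefore expected in this assay, in either direction.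

The expected step is a 1.1-fold lower number from compound 3 to compound 4 (0.03 log units; within the scatter). The estimate for compound 4 is 40000 nM, with an expected range of 19000 nM to 85000 nM.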

Compound 4, half-maximal inhibitory concentration: 49800 nM
Beside the measured number, compound 4's estimate is 1.2-fold (0.10 log units) below it, and the stated range covers the measured number.
By their numbers in this assay, from the lowest: compounds 1, 3, 4 and 2 (each within the scatter of the next, the first and the last beyond it).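

In this assay, 3-nitrophenyl to 3-methoxyphenyl is now a directly measured exchange with chloro on the shared core (a 1.2-fold higher number from compound 3 to compound 4 (0.07 log units; within the scatter)), and the two groups are not separated at this aromatic carbon. On the other side of the molecule, chloro in place of hydrogen (a 2.0-fold higher number from compound 1 to compound 4 (0.30 log units; within the scatter)) and chloro in place of methoxy (a 1.8-fold lower number from compound 2 to compound 4 (0.25 log units; within the scatter)) also stay within the scatter, so chloro is not separated from either of the groups it replaces there. No evidence is at hand that bears on these results.

Only nitro and methoxy are compared at the first aromatic carbon, so an amine or a carboxylic acid there remains an open case. On these data alone, whether any exchange at that carbon can give a step beyond the scatter also remains open.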